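The source may report more compounds than this note shows. Statements on the series, on what has been measured and on what is new or still open speak of the compounds shown alone.

Of the compounds shown here, two sharing one core have been measured so far in an ADME assay on A549 cells (Homo sapiens) for cytotoxicity, read by resazurin assay, with a stated time of 48 h; on this read-out lower numbers stand for higher toxicity in this test and higher numbers for lower toxicity in this test. In this test compound 1 `O=C(Nc1ccc(NCc2cc(F)cc(Cl)c2)cc1Cl)c1cc(Cl)ccc1O` gives 11100 nM, and compound 2 `O=C(Nc1ccc(NCc2cc(Cl)cc(Cl)c2)cc1Cl)c1cc(Cl)ccc1O` gives 13300 nM. These two numbers lie within the scatter of each other, so compound 2 stands level with compound 1, and neither can be called the more toxic.

Compound 3 `O=C(Nc1ccc(NCc2cc(Cl)cc(C(F)(F)F)c2)cc1Cl)c1cc(Cl)ccc1O` differs from compound 2 in a single group: trifluoromethyl in place of chloro on an aromatic carbon. Put simply, this is trifluoromethyl in place of chloro on an aromatic carbon, meta to a chloro group and meta to a large group.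

Going by the values given here, only one measured change offers a guide, a swap of chloro in place of fluoro on an aromatic carbon. It gives a 1.2-fold higher number from compound 1 to compound 2 (0.08 log units; within the scatter). Among the compounds with values here, no measured compound yet carries a trifluoromethyl group, so this guide is a loose one. In this assay a step no larger than the scatter is therefore expected, with no firm direction. The estimate is a 1.2-fold lower number from compound 2 to compound 3 (0.08 log units; within the scatter), which is expected to be indistinguishable from no change. Compound 3 is expected to give about 11000 nM, with an estimated range from 5500 nM to 23000 nM.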

Compound 3, half-maximal cytotoxic concentration: 30900 nM
Beside the measured number, compound 3's estimate is 2.8-fold (0.45 log units) below it, outside the stated range (above it).
By their numbers in this assay, from the lowest: compounds 1 and 2 (each within the scatter of the next); then compound 3.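

Going by these compounds alone, until now, the choice between fluoro and chloro at this position had produced no step that could be read in this assay, so the group on this aromatic carbon might have seemed to make little difference. Trifluoromethyl in place of chloro changes that picture: it gives a 2.3-fold higher number from compound 2 to compound 3 (0.37 log units; beyond the scatter), and since higher numbers here stand for lower toxicity in this test, compound 3 is the least toxic of the three. Trifluoromethyl in place of fluoro points the same way, with a 2.8-fold higher number from compound 1 to compound 3 (0.44 log units; beyond the scatter), so the step appears against both halogen-bearing compounds, although nothing shown here explains why the number moves.

The compounds shown leave open how other groups on this same carbon would read, such as an amine, a carboxylic acid, a methoxy group or a longer chain, and so whether the number keeps rising beyond trifluoromethyl or falls again. They also leave open whether trifluoromethyl would give a step of similar size if the chloro group on the same ring were replaced by something else, such as a nitrile.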